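This account rests on a few compounds, and the source may have more. Where it says the series, first, only, none or still open, it means among the compounds named here.

In an ADME assay on HaCaT cells (Homo sapiens) for inhibition, read by sulforhodamine B assay, with a stated time of 48 h (a higher number here means a weaker inhibitor of growth, a lower number a stronger inhibitor of growth), compound 1 (`CCOC(=O)c1nn(-c2ccc(Cl)cc2)c(-c2ccccc2)c1CNC(C)(C)C`) gives > 608000 nM; > 559000 nM (2 entries) as limits of the assay and not numbers. Compound 2 (`CC(C)(C)NCc1c(C(=O)O)nn(-c2ccc(Cl)cc2)c1-c1ccc(Br)cc1`) stands at > 542000 nM in this assay as a limit too, so no single number fixes its place. Compound 3 (`CC(C)(C)NCc1c(C(=O)O)nn(-c2ccc(Cl)cc2)c1-c1ccccc1`) follows from compound 2 with hydrogen in place of bromo on an aromatic carbon, para to a large group, so that 4-bromophenyl becomes phenyl (hydrogen in place of bromo on an aromatic carbon). Among the compounds with values here, no measured step shows what such a change does, and only limits are available to set it against. The expectation therefore rests on compound 2 at > 542000 nM as a limit and on the small size of the change. The expected step that the limit leaves unreadable from compound 2 to compound 3 is no larger than the usual scatter, in neither direction. A further limit rather than a number is the likely report for the next entry. In this assay the value expected for compound 3 is estimated at 650000 nM (range 350000 nM to 1000000 nM).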

Compound 3, concentration for 50% growth inhibition: 175000 nM
Beside the measured number, compound 3's estimate is 3.7-fold (0.57 log units) above it; measured number below the stated range.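

In this assay hydrogen in place of bromo on an aromatic carbon, para to a large group, gives an at least 3.0-fold lower number from compound 2 to compound 3 (0.49 log units; beyond the scatter) and yields the first single number in the series, so this position is now shown to affect the read-out. Compound 1 also carries phenyl at this position, with an ethyl ester in place of the carboxylic acid, and stands at > 608000 nM; > 559000 nM (2 entries) as limits of the assay and not numbers, so among the compounds shown phenyl gives a single number only together with the carboxylic acid. The step gives only a minimum size and not an exact one, because compound 2 is reported as a limit and not a number: the limit of > 542000 nM in this assay, at which 1 of the 3 values shown sits.

Going by these compounds, the full size of the step stays open, and so does whether the change depends on bromo itself, which fluoro, methyl or methoxy at the same place on the ring would test. No evidence here gives a reason for the lower number, and the compounds shown do not separate the part played by the carboxylic acid from that of the ethyl ester by any single number.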